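Inverting One Ring Stereocentre in a Clearance Series

A few compounds are considered here, and "the series" means these few. Any claim that something is new, unique, unknown or untested is made for them only; others in the source may bear on it.

Measured so far in an ADME assay on liver for metabolic stability, with Liver microsome (Homo sapiens) as the target, read by LC-MS, using microsomes, with a stated time of 5 h; a lower number here means slower removal, a higher number faster removal of the compound:
- Compound 1 `C[C@]1(O)C[C@@](c2cc(C(F)(F)F)ccn2)([C@H](O)c2ccccn2)C1` gives 33.3 mL/min/kg.
- Compound 2 `O[C@]1(c2ccccn2)CC[C@H](c2ccc(C(F)(F)F)cc2)C1` gives 333 mL/min/kg.
- Compound 3 `C[C@]1(O)C[C@@](c2ccnc(C(F)(F)F)c2)([C@H](O)c2ccccn2)C1` gives 66.7 mL/min/kg.

Among these three numbers compound 2 stands highest. Compound 3 is the nearest to it, yet still beyond the scatter below it, and compound 1 lies furthest below. The open question is how compound 4 `O[C@]1(c2ccccn2)CC[C@@H](c2ccc(C(F)(F)F)cc2)C1` will behave in this assay. Its relation to compound 2 is this: the two compounds have the same atoms and bonds and differ only in configuration as drawn: 1 of 2 stereo elements differ; a stereocentre at a saturated ring carbon is drawn S in compound 2 and R in compound 4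

For the measured compounds named here, no pair of measured compounds differs in only one place, so there is no measured step to lean on, and nothing among the three numbers shows how a change of configuration alone moves the read-out. The expectation is a step of uncertain direction and limited size, so a 1.1-fold lower number from compound 2 to compound 4 (0.05 log units; within the scatter) is estimated as a change that may well stay within the scatter. Compound 4 is therefore expected near 300 mL/min/kg, within a range from 120 mL/min/kg to 750 mL/min/kg.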

Compound 4, clearance: 383 mL/min/kg
Compound 4: middle estimate off by 1.3-fold (0.11 log units), on the low side; measured number inside the range.
By their numbers in this assay, from the lowest: compounds 1 and 3 (each within the scatter of the next); then compounds 2 and 4 (each within the scatter of the next).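

In this assay, inverting this saturated ring carbon gives a 1.2-fold higher number from compound 2 to compound 4 (0.06 log units; within the scatter), so the two numbers cannot be told apart. For the compounds shown here, this is the first step in the set that can be read as one isolated change, and it is a clean test of configuration alone: the fact that compounds 2 and 4 differ only in the configuration as drawn. For this pair, therefore, whether the ring carbon is drawn S or R makes no difference that this assay can resolve, and the fast removal seen for compound 2 is seen for compound 4 as well.

This single pair cannot show whether configuration at this carbon would remain as unimportant if the trifluoromethyl group gave way to an amine or a carboxylic acid. From the compounds shown here alone, the role of the second stereo element, drawn the same way in compound 2 and compound 4, also stays open.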